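This account rests on a few compounds, and the source may have more. Where it says the series, first, only, none or still open, it means among the compounds named here.

Compound 1, with structure `COC(=O)c1ccc(NCc2cncn2Cc2ccc(Cl)cc2)cc1-c1ccccc1`, was tested in a toxicity assay on NIH3T3 cells (Mus musculus) for cytotoxicity, read by resazurin assay (on this read-out lower numbers stand for an effect already at smaller amounts and higher numbers for an effect only at larger amounts of compound), where compound 1 gives 25000 nM. Among the three results shown for this set, that is the only outright number; the other two are limits. Compound 2, `Clc1ccc(NCc2cncn2Cc2ccc(-c3ccccc3)cc2)cc1-c1ccccc1`, is one of them: in this assay compound 2 gives > 1000 nM, which is a limit of the assay and not a number. Compound 3, `c1ccc(-c2ccc(Cn3cncc3CNc3ccc(-c4ccccc4)c(-c4ccccc4)c3)cc2)cc1`, differs from compound 2 by a phenyl in place of chloro on an aromatic carbon; in this assay compound 3 gives > 10000 nM, again a limit rather than a number. The step that the two limits leave unreadable from compound 2 to compound 3 is therefore unreadable in size: one end rests at the limit of > 1000 nM in this assay, at which 1 of the 3 values shown sits, and the other at the limit of > 10000 nM in this assay, at which 1 of the 3 values shown sits.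

The compound not yet measured, compound 4 with structure `COC(=O)c1ccc(NCc2cncn2Cc2ccc([N+](=O)[O-])cc2)cc1-c1ccccc1`, comes from compound 1 by nitro in place of chloro on an aromatic carbon. Within the data shown here, none of the measured steps concerns a change of chloro to nitro, and the one measured step in this set offers no readable size. The data thus give no grounds to expect a shift in this assay in either direction beyond the scatter. The expected result for compound 4 is 25000 nM, with a range from 8000 nM to 80000 nM. This estimate means an expected step of no change at the digits printed from compound 1 to compound 4 (within the scatter), lying within the usual scatter.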

Compound 4, half-maximal effective concentration: > 10000 nM
Compound 4 ended at the assay's limit; the forecaster's own chance of this, stated with the estimate: 35%; the middle value lies beyond the limit too.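

The result for compound 4 is a limit of the assay and not a number, and the size of the change from compound 1 to compound 4 cannot be read. The compounds shown leave open where compound 4 truly lies in this assay, and whether nitro in place of chloro changes the result there at all.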